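Sulfur for Oxygen in the Sulfonyl Side Chain

A few compounds are considered here, and "the series" means these few. Any claim that something is new, unique, unknown or untested is made for them only; others in the source may bear on it.

Measured compounds:
compound 1 `COc1ccc(C2=NN(c3ccccc3)C(c3ccc(C)cc3)C2S(=O)(=O)CC2=NCCO2)cc1`: 62.5%
compound 2 `O=S(=O)(CC1=NCCS1)c1c(-c2ccc(Cl)cc2)noc1-c1ccc(Cl)cc1`: "not active" (no number reported)
compound 3 `O=S(=O)(CC1=NCCO1)c1n[nH]cc1-c1ccc(Cl)cc1`: "not active" (no number reported)

In a functional assay, tested at 50 ug/mL (a lower number here means a weaker effect, a higher number a stronger effect of the compound at the concentration tested), compound 1 gives 62.5%, the only figure reported in this set. Compound 2 gives "not active" (no number reported) without a number. Compound 3 likewise gives "not active" (no number reported) without a number. Compound 1 therefore stands alone as the single quantified result.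

Compound 4 `COc1ccc(C2=NN(c3ccccc3)C(c3ccc(C)cc3)C2S(=O)(=O)CC2=NCCS2)cc1` differs from compound 1 by a group of 5 heavy atoms (3 carbon, 1 nitrogen, 1 sulfur; one five-membered non-aromatic ring with 2 hetero atoms) in place of a group of 5 heavy atoms (3 carbon, 1 nitrogen, 1 oxygen; one five-membered non-aromatic ring with 2 hetero atoms), on a saturated chain carbon bound to a sulfonyl sulfur. Among the measured compounds shown here, no pair of measured compounds separates this change by itself, so no measured step guides the expectation. Keeping the core of compound 1, the step is expected to be small, at most a modest decrease, with a number 7.5 percentage points lower from compound 1 to compound 4 (within the scatter) as the estimated change in this assay. Compound 4 is expected to give about 55%, within a range from 35% to 75%.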

Compound 4, a percentage reported as activity, at one concentration (the size of the read-out at that concentration, not a potency): 42.6%
Compound 4: middle estimate off by 12.4 percentage points, on the high side; the range from low to high includes it.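

With the core of compound 1 held constant, this position responds to a single-atom exchange: in this assay, replacing the ring oxygen with sulfur gives a number 19.9 percentage points lower from compound 1 to compound 4 (beyond the scatter). The sulfur-containing compound 4 still gives a measurable read-out, so activity at this concentration does not depend strictly on the ring oxygen. Nothing available explains the loss. From the compounds shown here alone, whether an imidazoline ring, with a second nitrogen in place of the oxygen or sulfur, or an open-chain amine would restore the read-out remains open.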